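The source may report more compounds than this note shows. Statements on the series, on what has been measured and on what is new or still open speak of the compounds shown alone.

Of the compounds shown here, three built on a shared core have been measured in an ADME assay on the whole organism (Mus musculus, strain BALB/C) for pharmacokinetics, read by LC-MS, with a stated time of 24 h, at a dose of 1 mg/kg by the intravenous route; on this read-out higher numbers stand for higher exposure at the dose given and lower numbers for lower exposure. Compound 1 `C[C@H](Nc1nc(N)nc(N)c1C#N)c1cc(=O)n2cc(F)ccc2c1-c1cc(F)cc(F)c1` gives 1100 nM, compound 2 `Cc1c([C@H](C)Nc2nc(N)nc(N)c2C#N)c(-c2ccccc2)c(=O)n2cc(F)ccc12` gives 1300 nM, and compound 3 `C[C@H](Nc1nc(N)nc(N)c1C#N)c1c(-c2ccccc2)c(=O)n2cc(F)ccc2c1C1CC1` gives 1400 nM. Compound 2 thus sits among numbers that all lie within the scatter of one another, close to compound 3 and to compound 1 alike. Within the data shown here, the only single-point step among them, a 1.1-fold higher number from compound 2 to compound 3 (0.03 log units; within the scatter), stays within the scatter. Compound 4 `C[C@H](Nc1nc(N)nc(N)c1C#N)c1c(-c2ccccc2)c(=O)n2cc(F)ccc2c1-c1ccc(F)cc1` differs from compound 2 by 4-fluorophenyl in place of methyl on an aromatic carbon. Among the measured compounds shown here, no measured step covers an aromatic ring entering at this point; the one comparison available, methyl to cyclopropyl, showed nothing beyond the scatter. Compound 4 is therefore expected to give no step beyond the scatter in this assay, a 1.1-fold lower number from compound 2 to compound 4 (0.03 log units; within the scatter). The estimate for compound 4 is 1200 nM, with a range from 500 nM to 3000 nM.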

Compound 4, maximal plasma concentration: 2300 nM
Compound 4: middle estimate off by 1.9-fold (0.28 log units), on the low side; the measured number falls inside the stated range.
By their numbers in this assay, from the lowest: compounds 1, 2, 3 and 4 (each within the scatter of the next, the first and the last beyond it).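

In this assay, 4-fluorophenyl on this aromatic carbon gives a 1.8-fold higher number from compound 2 to compound 4 (0.25 log units; within the scatter) in place of methyl and a 1.6-fold higher number from compound 3 to compound 4 (0.22 log units; within the scatter) in place of cyclopropyl as the other comparison. The earlier pair covered only methyl and cyclopropyl, whereas this result shows that a group of 7 heavy atoms carrying an aromatic ring also brings no step beyond the scatter here. Nothing available explains the result.

Going by these compounds, whether an unsubstituted phenyl, a pyridine, an amine or a carboxylic acid at this carbon would also stay within the scatter remains open.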